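The source may report more compounds than this note shows. Statements on the series, on what has been measured and on what is new or still open speak of the compounds shown alone.

Measured compounds:
compound 1, `N#Cc1cc(C(=O)N2CCc3ccccc32)cc(I)c1O`, 5300 nM in an assay on tissue (RPTEC cells) for inhibition of solute carrier family 22 member 12 (Homo sapiens), read by scintillation counting, with stated times of 15 min and 2 h; on this read-out higher numbers stand for weaker inhibition and lower numbers for stronger inhibition
compound 2, `N#Cc1cc(C(=O)N2CCc3ccccc32)cc(C2CC2)c1O`, 8800 nM
compound 3, `N#Cc1cc(C(=O)N2CS(=O)(=O)c3ccccc32)cc(C2CC2)c1O`, 19200 nM

Compound 3 has the highest number of the three in this assay; its nearest neighbour is compound 2, and compound 1 lies furthest from it. Compound 4, `N#Cc1cc(C(=O)N2CS(=O)(=O)c3ccccc32)cc(C(F)(F)F)c1O`, keeps the core of compound 3 and differs from it in one place: trifluoromethyl in place of cyclopropyl on an aromatic carbon.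

Going by the values given here, only one measured step exists here, a 1.7-fold higher number from compound 1 to compound 2 (0.22 log units; within the scatter), and it concerns a different exchange on the same carbon; no measured pair shows trifluoromethyl against cyclopropyl. So nothing in these data points to a change beyond the scatter in either direction, and the expected step from compound 3 is a 1.0-fold lower number from compound 3 to compound 4 (0.00 log units; within the scatter), with a wide margin around it. Compound 4 is therefore expected to give about 19000 nM in this assay, estimated somewhere between 6000 nM and 60000 nM.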

Compound 4, half-maximal inhibitory concentration: > 100000 nM
Compound 4 gave a limit, no number; the forecaster's own chance of this, stated with the estimate: 15%; middle value at least 5.2-fold (0.72 log units) from the limit.
By their numbers in this assay, from the lowest: compounds 1 and 2 (each within the scatter of the next); then compound 3. At a limit, above all of these: compound 4.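

In this assay, the carbon ortho to a hydroxy group proves sensitive to what it carries: with the core of compound 3 kept, trifluoromethyl in place of cyclopropyl gives an at least 5.2-fold higher number from compound 3 to compound 4 (0.71 log units; beyond the scatter). Going by these compounds alone, the only earlier exchange on this carbon, cyclopropyl in place of iodo on a different core, gave a 1.7-fold higher number from compound 1 to compound 2 (0.22 log units; within the scatter), so it showed no change that could be told from the scatter. Compound 4 is read only as a limit, not as a number: the limit of > 100000 nM in this assay, at which 1 of the 4 values shown sits.

The compounds shown leave open whether the same exchange would have a similar effect on the core of compound 1. They also leave open how a carboxylic acid, an amine or a longer chain on this carbon would read in this assay.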